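From a Carboxy Group to an Aminocarbamoyl Group

This account rests on a few compounds, and the source may have more. Where it says the series, first, only, none or still open, it means among the compounds named here.

Three measured compounds share the core of compound 1 `CCOC(=O)/C=C/c1ccncc1-c1ccc2c(ccn2C)c1`. In a functional assay on HCT-116 cells (Homo sapiens) for inhibition, read by MTT assay, with a stated time of 72 h (on this read-out lower numbers stand for stronger inhibition of growth and higher numbers for weaker inhibition of growth), compound 1 gives 210 nM. Compound 3 `O=C(/C=C/c1ccncc1-c1ccc2cccnc2c1)N1CCOCC1` has no result in this assay, recorded as "not determined" (no result reported). Compound 2 `O=C(O)CCc1ccncc1-c1ccc2ccccc2c1` reaches only the limit of this assay, giving > 30000 nM, and thus stands at the weak end of the values shown (the limit of > 30000 nM in this assay, at which 1 of the 3 values shown sits). Compound 4 `NNC(=O)CCc1ccncc1-c1ccc2ccccc2c1` differs from compound 2 in one place (aminoamino in place of hydroxy on a carbonyl carbon), carboxy becoming aminocarbamoyl. Within the data shown here, no measured pair shows this change, so its direction and size are open. Compound 4 is expected to give about 10000 nM, likely between 1500 nM and 30000 nM. That estimate means an expected step of an at least 3.0-fold lower number from compound 2 to compound 4 (0.47 log units; beyond the scatter) toward stronger inhibition of growth, with a real chance that compound 4 again shows only a limit.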

Compound 4, concentration for 50% growth inhibition: > 30000 nM
Compound 4: only a limit was reported; the forecaster's own chance of this, stated with the estimate: 40%; middle value at least 3.0-fold (0.47 log units) away from the limit.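

Compound 2 and compound 4 both give only a limit in this assay, so no step can be read between them: the limit of > 30000 nM in this assay, at which 2 of the 4 values shown sit.

The compounds shown leave open whether aminocarbamoyl in place of carboxy changes inhibition of growth at all.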